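Predicting an Aryl Amine Swap from One Measured Pair

The source may report more compounds than this note shows. Statements on the series, on what has been measured and on what is new or still open speak of the compounds shown alone.

Of the compounds shown here, three have so far been measured in a functional assay on MGC-803 cells (Homo sapiens) for inhibition, read by MTT assay, with a stated time of 72 h; on this read-out higher numbers stand for weaker inhibition and lower numbers for stronger inhibition. Compound 1 `COc1cc(-c2nc(SCc3cn(CC(=O)NC(=O)Nc4ccccn4)nn3)nc(Nc3ccc(C(C)C)cc3)c2C#N)cc(OC)c1OC` gives 35500 nM, compound 2 `COc1cc(-c2nc(SCc3cn(CC(=O)NC(=O)Nc4ccccn4)nn3)nc(Nc3cccc(C(F)(F)F)c3)c2C#N)cc(OC)c1OC` gives 8210 nM, and compound 3 `N#Cc1c(Nc2cccc(C(F)(F)F)c2)nc(SCc2cn(CC(=O)NC(=O)Nc3ccccn3)nn2)nc1-c1ccc(Br)cc1` gives 3600 nM in this assay. Compound 1 and compound 2 differ by 4-isopropylphenyl in place of 3-(trifluoromethyl)phenyl on a nitrogen on an aromatic ring, and that change produced a 4.3-fold higher number from compound 2 to compound 1 (0.64 log units; beyond the scatter). Compound 2 and compound 3 differ in their cores by 4-bromophenyl in place of 3,4,5-trimethoxyphenyl on an aromatic carbon, a change that produced a 2.3-fold lower number from compound 2 to compound 3 (0.36 log units; beyond the scatter), leaving compound 3 with the lowest number of the three. Compound 4 `CC(C)c1ccc(Nc2nc(SCc3cn(CC(=O)NC(=O)Nc4ccccn4)nn3)nc(-c3ccc(Br)cc3)c2C#N)cc1` has not yet been measured; it differs from compound 3 by 4-isopropylphenyl in place of 3-(trifluoromethyl)phenyl on a nitrogen on an aromatic ring, the same change as between compound 2 and compound 1, at the same place, but now on the core of compound 3. Because this same change gave a 4.3-fold higher number from compound 2 to compound 1 (0.64 log units; beyond the scatter), the expected step here is a 4.3-fold higher number from compound 3 to compound 4 (0.63 log units; beyond the scatter), about the same size, though it rests on a single measured pair on a different core. Compound 4 is therefore estimated at 15500 nM, with a likely range from 6000 nM to 40000 nM.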

Compound 4, half-maximal inhibitory concentration: 15600 nM
Compound 4: the middle estimate sits 1.0-fold (0.00 log units) below what was measured; the measured number falls inside the stated range.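

On the core of compound 3, putting 4-isopropylphenyl in place of 3-(trifluoromethyl)phenyl gave a 4.3-fold higher number from compound 3 to compound 4 (0.64 log units; beyond the scatter) in this assay, and this step matches the one seen on the core of compound 2: the same change on two cores in this assay, a 4.3-fold higher number (0.64 log units; beyond the scatter) from compound 2 to compound 1 and a 4.3-fold higher number (0.64 log units; beyond the scatter) from compound 3 to compound 4, 1.0-fold (0.00 log units) apart, within the scatter of two such steps. Read the other way, 4-bromophenyl in place of 3,4,5-trimethoxyphenyl gave a 2.3-fold lower number from compound 1 to compound 4 (0.36 log units; beyond the scatter), which again matches the earlier step: the same change on two cores in this assay, a 2.3-fold lower number (0.36 log units; beyond the scatter) from compound 2 to compound 3 and a 2.3-fold lower number (0.36 log units; beyond the scatter) from compound 1 to compound 4, 1.0-fold (0.00 log units) apart, within the scatter of two such steps. Across these four compounds, then, each change kept its size when carried to the other core, but this covers only two groups at each of the two places and does not show why the steps agree or that other changes in this series would carry over as well.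

The compounds shown leave open whether the same agreement would hold for other groups on the nitrogen, such as a 4-methoxyphenyl or a cyclohexyl group. On these data alone, it also remains open whether a plain phenyl on the aromatic carbon would behave like the two groups seen there.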